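Dropping the ortho chlorine from a benzylamine sulfonamide

The source may hold more compounds than are shown below. What is called first, only, known or untested is meant among the compounds shown, and "the series" means these compounds.

The series shares the core of compound 1, `O=S(=O)(NCCCNCc1ccccc1Cl)c1cc(C(F)(F)F)cc(C(F)(F)F)c1`, a bis(trifluoromethyl)benzenesulfonamide joined through a three-carbon chain to a benzylic amine. In a functional assay on HPAC cells (Homo sapiens) for inhibition, read by MTT assay, with a stated time of 72 h (a higher number here means a weaker inhibitor of growth, a lower number a stronger inhibitor of growth), compound 1 gives 10000 nM, the second highest of the three numbers recorded. Compound 2, `O=S(=O)(NCCCNCC1COc2ccccc2O1)c1cc(C(F)(F)F)cc(C(F)(F)F)c1`, gives 2700 nM, and compound 3, `CN(CCCNS(=O)(=O)c1cc(C(F)(F)F)cc(C(F)(F)F)c1)Cc1ccccc1`, gives 30000 nM.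

Compound 4, `O=S(=O)(NCCCNCc1ccccc1)c1cc(C(F)(F)F)cc(C(F)(F)F)c1`, differs from compound 1 in one place: hydrogen in place of chloro on an aromatic carbon.

Two measured steps start from compound 1. The step of a 3.7-fold lower number from compound 1 to compound 2 (0.57 log units; beyond the scatter) exchanges the whole aryl group, and the step of a 3.0-fold higher number from compound 1 to compound 3 (0.48 log units; beyond the scatter) alters the amine itself; neither removes a single substituent while leaving the rest of the benzylamine untouched, so neither bears directly on the change to compound 4. Both steps were modest, and a single chlorine is a smaller edit than either. A step of no more than about the scatter is therefore expected, with no clear direction, and the estimate for compound 4 is 12000 nM, spanning 4000 nM to 35000 nM, which amounts to the expected step of a 1.2-fold higher number from compound 1 to compound 4 (0.08 log units; within the scatter).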

Compound 4, concentration for 50% growth inhibition: 3200 nM
The estimate for compound 4 lay 3.8-fold (0.57 log units) above the measured number, and the stated range ends above it.
By their numbers in this assay, from the lowest: compounds 2 and 4 (each within the scatter of the next); then compound 1; then compound 3.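

In this assay, the step of a 3.1-fold lower number from compound 1 to compound 4 (0.49 log units; beyond the scatter) shows that removing the single chloro from the aromatic carbon matters beyond the scatter, and the step runs towards a stronger inhibitor of growth. The step of a 9.4-fold lower number from compound 3 to compound 4 (0.97 log units; beyond the scatter) isolates hydrogen in place of methyl on the amine nitrogen and is the largest of the new steps, so the earlier comparison of compound 1 with compound 3 had combined two changes pulling in opposite directions. The step of a 1.2-fold higher number from compound 2 to compound 4 (0.07 log units; within the scatter) lies within the scatter, so plain phenyl and 2,3-dihydro-1,4-benzodioxin-2-yl cannot be told apart here.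

The compounds shown leave open whether a fluorine or a methoxy group in place of the chloro would behave like the chloro or like hydrogen. No measurement at hand accounts for any of these steps.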